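The compounds below may be only part of what the source reports. "The series", "measured", "known", "first", "only" and "open" are said of these compounds alone.

In a functional assay on HL-60 cells (Homo sapiens) for cytotoxicity, read by WST assay, with a stated time of 48 h (on this read-out higher numbers stand for weaker inhibition and lower numbers for stronger inhibition), compound 1 `COc1cc(C(c2ccc(O)c(OC)c2)[C@@H](C)[C@@H](C)CO)ccc1O` gives > 100000 nM, which is a limit of the assay. Compound 2 `COc1cc(C(c2ccc(O)c(OC)c2)[C@@H](CO)C(C)C)ccc1O` gives > 100000 nM, also a limit. Among the compounds with values here, compound 3 `CC[C@H](C(C)C)C(c1ccc(O)c(OC)c1)c1ccc(O)c(OC)c1` gives 16000 nM, the only actual number in the set.

Compound 4 `COc1cc(C(c2ccc(O)c(OC)c2)[C@H](CO)C(C)C)ccc1O` differs from compound 3 by hydroxy in place of methyl on a saturated chain carbon, three bonds along the chain from two aromatic carbons, which can also be read as ethyl to hydroxymethyl.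

The closest measured evidence is an at least 6.2-fold lower number from compound 2 to compound 3 (0.79 log units; beyond the scatter), which runs this same exchange of groups in the opposite direction. A related change appears in an at least 6.2-fold lower number from compound 1 to compound 3 (0.79 log units; beyond the scatter). From the compounds shown here alone, both steps start from limits, so their full size remains open, while a step that the two limits leave unreadable from compound 1 to compound 2 adds no size at all.

A move toward weaker inhibition in this assay is therefore expected, and the estimated change is a 7.5-fold higher number from compound 3 to compound 4 (0.88 log units; beyond the scatter). Compound 4 is expected to lie near 120000 nM, within an estimated range of 40000 nM to 400000 nM.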

Compound 4, half-maximal inhibitory concentration: > 100000 nM
Compound 4 gave a limit, no number; the forecaster's own chance of this, stated with the estimate: 75%; the middle value does not contradict the limit.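

In this assay, hydroxy in place of methyl on a saturated chain carbon, three bonds along the chain from two aromatic carbons, gives an at least 6.2-fold higher number from compound 3 to compound 4 (0.79 log units; beyond the scatter). The earlier compounds shown here showed weaker inhibition with this change only for compound 2, drawn S at the stereocentre, and compound 4 shows it for the form drawn R as well. The steps among compound 1, compound 2 and compound 4 cannot be read, so no effect of the drawn configuration can be sized for the pair: the fact that compounds 2 and 4 differ only in the configuration as drawn. The full size of the step from compound 3 also stays open: the limit of > 100000 nM in this assay, at which 3 of the 4 values shown sit.

The compounds shown leave open whether an amine or a methoxy group at this place would keep the number of compound 3, 16000 nM. Also open, from the compounds shown here alone, is whether a longer chain in place of ethyl would move that number at all.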